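From pyridin-3-yl to 5-bromothiophen-2-yl at the carbonyl

The source may hold more compounds than are shown below. What is called first, only, known or untested is meant among the compounds shown, and "the series" means these compounds.

Three compounds sharing one core were tested in an assay for inhibition of Maternal embryonic leucine zipper kinase (Homo sapiens), read by ADP-Glo, with a stated time of 0.5 h; a higher number here means a weaker inhibitor, a lower number a stronger inhibitor. Compound 1 `COc1ccc(C(=O)c2sc(NC(C)C)c(C#N)c2N)cc1OC` gives 1770 nM. Compound 2 `CC(C)Nc1sc(C(=O)c2ccc(C#N)cc2)c(N)c1C#N` reaches only a limit of the assay, > 5000 nM. Compound 3 `CC(C)Nc1sc(C(=O)c2cccnc2)c(N)c1C#N` likewise gives only a limit, > 5000 nM. Among the three values shown, compound 3 therefore sits at the limit of > 5000 nM in this assay, at which 2 of the 3 values shown sit. Compound 4 `CC(C)Nc1sc(C(=O)c2ccc(Br)s2)c(N)c1C#N` has not yet been measured; it differs from compound 3 by 5-bromothiophen-2-yl in place of pyridin-3-yl on a carbonyl carbon. For the measured compounds named here, no measured pair shows what such an exchange does on this core, so the expected step is a number no higher from compound 3 to compound 4 (the limit leaves the size open), which is not beyond the usual scatter. The estimate for compound 4 in this assay is 5000 nM, expected to fall between 1200 nM and 20000 nM.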

Compound 4, half-maximal inhibitory concentration: 122 nM
Compound 4: middle estimate off by 41-fold (1.61 log units), on the high side, outside the stated range (below it).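

In this assay, the group on the carbonyl carbon proves able to move activity on this core a long way: the exchange gives an at least 40-fold lower number from compound 3 to compound 4 (1.61 log units; beyond the scatter). Both groups hold 6 heavy atoms, so this gain comes with no added heavy atoms. The step starts from a limit and not from a number, so its full size stays unknown: the limit of > 5000 nM in this assay, at which 2 of the 4 values shown sit.

Going by these compounds, whether the gain belongs to the bromine or to the thiophene ring stays open. A plain thiophen-2-yl or a 5-chlorothiophen-2-yl group on the carbonyl would help separate the two.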